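The compounds below may be only part of what the source reports. "The series", "measured", "known", "first", "only" and "open" are said of these compounds alone.

In an ADME assay on HepG2 2.2.15 cells (Homo sapiens) for cytotoxicity (on this read-out higher numbers stand for lower toxicity in this test and lower numbers for higher toxicity in this test), three members of this series have been examined, none of which gave a single number. Compound 1 `CC(C)(C)OC(=O)Nc1ncc(C(Oc2ccc(OCc3ccccc3)cc2)c2ccc(Cl)cc2)s1` is described only by a limit of the assay, > 50000 nM. Compound 2 `COc1ccc(Br)c(COC(c2ccccc2)c2cnc(NC(=O)c3cccs3)s2)c1` is reported in this assay as "not toxic" (no number reported), without a number. Compound 3 `COCCNc1ncc(C(Oc2ccc3cc(Br)ccc3c2)c2ccc(Cl)cc2)s1` is likewise recorded in this assay as "not toxic" (no number reported). Compound 3 thus stands among three entries that all point the same way. Compound 1 sits at the limit of > 50000 nM in this assay, at which 1 of the 3 values shown sits. With no number for compound 3 itself, its place within the range can only be stated as unmeasured or beyond reach.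

Compound 4 `COc1ccc(C(=O)Nc2ncc(C(Oc3ccc4cc(Br)ccc4c3)c3ccc(Cl)cc3)s2)cc1` has not yet been tested in this assay. It differs from compound 3 in one place: (4-methoxyphenyl)carbonyl in place of 2-methoxyethyl on a nitrogen on an aromatic ring. Going by the values given here, no step between two measured compounds of this kind is available, so the size of the change in this assay cannot be read from the data. Given that compound 1, compound 2 and compound 3 all fall at or beyond the reach of this assay, the expectation is of no step beyond the scatter, with compound 4 also low in toxicity. For compound 4 the estimated value in this assay is 50000 nM, expected to fall between 20000 nM and 120000 nM.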

Compound 4, half-maximal cytotoxic concentration: > 50000 nM
Compound 4: a limit, no number (the forecaster's own chance of this, stated with the estimate: 70%); the middle value sits exactly at the limit.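

Going by these compounds alone, compound 3 has no number in this assay and the result for compound 4 is only a limit, so no step between compound 3 and compound 4 can be read. The compounds shown leave open the actual half-maximal cytotoxic concentration of each and whether any change in structure alters it, with the readings stopping at one point: the limit of > 50000 nM in this assay, at which 2 of the 4 values shown sit.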